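A few compounds are considered here, and "the series" means these few. Any claim that something is new, unique, unknown or untested is made for them only; others in the source may bear on it.

Measured compounds and their values:

Compound 1, `NS(=O)(=O)c1ccc(N/C=C\C(=O)c2cc3ccccc3oc2=O)cc1`, gives 109000 nM.
Compound 2, `O=C(/C=C\Nc1ccc(S(=O)(=O)Nc2ccccn2)cc1)c1cc2ccccc2oc1=O`, gives 37600 nM.
Compound 3, `O=C(/C=C\Nc1ccc(S(=O)(=O)Nc2ncccn2)cc1)c1cc2ccccc2oc1=O`, gives 75200 nM.

All three share one core and differ only in the group carried on the sulfonamide nitrogen. In a functional assay on T47D cells (Homo sapiens) for cytotoxicity, read by sulforhodamine B assay, with a stated time of 48 h (on this read-out higher numbers stand for weaker inhibition and lower numbers for stronger inhibition), compound 3 stands second highest of the three numbers; its value lies within the scatter of compound 1 on one side and of compound 2 on the other, so no order among these two neighbours can be claimed for it.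

Compound 4, `Cc1cc(C)nc(NS(=O)(=O)c2ccc(N/C=C\C(=O)c3cc4ccccc4oc3=O)cc2)n1`, is the next member of the series. The change from compound 3 is 4,6-dimethylpyrimidin-2-yl in place of pyrimidin-2-yl on a sulfonamide nitrogen.

Of the measured steps, the one from hydrogen to a pyridin-2-yl group, a 2.9-fold lower number from compound 1 to compound 2 (0.46 log units; beyond the scatter), is the only one that reached beyond the scatter. The step to pyrimidin-2-yl, a 1.4-fold lower number from compound 1 to compound 3 (0.16 log units; within the scatter), and the exchange of the two heteroaryl groups, a 2.0-fold higher number from compound 2 to compound 3 (0.30 log units; within the scatter), both stayed within it. Within the data shown here, none of these steps adds methyl groups to the ring, so no measured step speaks directly to the change at hand. Given how little the ring changes have moved the numbers so far, the expectation for compound 4 in this assay is a step of about a 1.5-fold lower number from compound 3 to compound 4 (0.18 log units; within the scatter), leaning lower but not clearly beyond the scatter. Compound 4 is therefore estimated at 50000 nM, with a range from 20000 nM to 150000 nM.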

Compound 4, half-maximal inhibitory concentration: 62200 nM
Beside the measured number, compound 4's estimate is 1.2-fold (0.09 log units) below it; the range from low to high includes it.
By their numbers in this assay, from the lowest: compounds 2, 4, 3 and 1 (each within the scatter of the next, the first and the last beyond it).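

In this assay the two methyl groups that turn pyrimidin-2-yl into 4,6-dimethylpyrimidin-2-yl on the sulfonamide nitrogen give a 1.2-fold lower number from compound 3 to compound 4 (0.08 log units; within the scatter) so enlarging the group from 6 to 8 heavy atoms leaves the read-out effectively where it was. Compound 4 also stays within the scatter of both other compounds, with a 1.7-fold higher number from compound 2 to compound 4 (0.22 log units; within the scatter) and a 1.8-fold lower number from compound 1 to compound 4 (0.24 log units; within the scatter) so this larger group cannot be told apart from pyridin-2-yl or even from the plain hydrogen on that nitrogen. Nothing measured here offers an explanation for how closely these values lie together.

Every group shown on this nitrogen is either hydrogen or an aromatic ring, so it remains open whether a non-aromatic group such as acetyl, or a five-membered ring such as thiazol-2-yl, would move the number beyond the scatter. Among these compounds, also open is what a methyl group on the pyridin-2-yl ring would do, given that the only step beyond the scatter in this small set is a 2.9-fold lower number from compound 1 to compound 2 (0.46 log units; beyond the scatter) and that all of these values lie in a similarly weak range.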